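Benzylsulfanyl aryl swap on the sulfonylguanidine hydrazone series

A few compounds are considered here, and "the series" means these few. Any claim that something is new, unique, unknown or untested is made for them only; others in the source may bear on it.

Of the compounds shown here, three have been measured in a functional assay on HCT-116 cells (Homo sapiens) for antiproliferative activity, read by MTT assay, with a stated time of 72 h; a lower number here means a stronger inhibitor, a higher number a weaker inhibitor. Compound 2 `Cc1cccc(CSc2cc(Cl)c(C)cc2S(=O)(=O)/N=C(\N)N/N=C/C#Cc2ccccc2)c1` gives 18000 nM, the lowest number of the three. Compound 1 `C/C(C#Cc1ccccc1)=N\N/C(N)=N/S(=O)(=O)c1cc(C)c(Cl)cc1SCc1ccccc1C` gives 142000 nM, and compound 3 `C/C(C#Cc1ccccc1)=N\N/C(N)=N/S(=O)(=O)c1cc(C)c(Cl)cc1SCc1cccc(C)c1` gives 160000 nM. The difference between compound 2 and compound 3 lies on the hydrazone carbon, an 8.9-fold higher number from compound 2 to compound 3 (0.95 log units; beyond the scatter). The difference between compound 1 and compound 3 sits on the saturated chain carbon bound to a sulfur, a 1.1-fold higher number from compound 1 to compound 3 (0.05 log units; within the scatter).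

Compound 4 `Cc1cc(S(=O)(=O)/N=C(\N)N/N=C/C#Cc2ccccc2)c(SCc2ccc(C(F)(F)F)cc2)cc1Cl` is not yet measured. Relative to compound 2 the change is 4-(trifluoromethyl)phenyl in place of 3-methylphenyl on a saturated chain carbon bound to a sulfur. Within the data shown here, only the step from compound 1 to compound 3 touches the same place, and it stayed within the scatter; no measured step carries a trifluoromethyl group anywhere. On that basis a change of the same kind is expected for compound 4: none beyond the scatter, a 1.1-fold higher number from compound 2 to compound 4 (0.05 log units; within the scatter), with the range widened for the untested group. Compound 4 is therefore estimated at 20000 nM in this assay, between 6000 nM and 70000 nM.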

Compound 4, half-maximal inhibitory concentration: 70000 nM
The estimate for compound 4 lay 3.5-fold (0.54 log units) below the measured number; measured number inside the range.
By their numbers in this assay, from the lowest: compound 2; then compound 4; then compounds 1 and 3 (each within the scatter of the next).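

In this assay the aryl group on the saturated chain carbon bound to a sulfur is not silent: 4-(trifluoromethyl)phenyl in place of 3-methylphenyl gives a 3.9-fold higher number from compound 2 to compound 4 (0.59 log units; beyond the scatter). Among these compounds, the only earlier step at this place, a 1.1-fold higher number from compound 1 to compound 3 (0.05 log units; within the scatter), changed 2-methylphenyl to 3-methylphenyl on compounds with a methyl group on the hydrazone carbon, so the two steps differ in both the change and the background. No measured evidence bears on the origin of the new step.

The new step changes the group and its place on the ring together, and the compounds shown do not separate the two. From the compounds shown here alone, how an unsubstituted phenyl group or a chlorophenyl group would read at this carbon stays open, as does whether the step carries over to compounds with a methyl group on the hydrazone carbon.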